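The compounds below may be only part of what the source reports. "The series", "measured", "known", "first", "only" and "open" are said of these compounds alone.

Series, measured in an ADME assay on HEK-293T cells (Homo sapiens) for cytotoxicity, read by CCK-8 assay, with a stated time of 48 h; a higher number here means that more compound is tolerated, a lower number that less compound is tolerated:

Compound 1 `Cn1cc(SCC(=O)Nc2ccccc2Cl)c2ccccc21` gives a limit, > 100000 nM.
Compound 2 `O=C(CSc1c[nH]c2cc(Cl)ccc12)Nc1ccc(Cl)c(Cl)c1` gives 67800 nM.
Compound 3 `CCOc1ccccc1NC(=O)CSc1c[nH]c2cccc(Cl)c12` gives 25200 nM.

Compound 3 stands lowest of the two numbers shown in this assay; compound 2 sits above it by a gap beyond the scatter, and compound 1 is reported only as a limit, as noted in the limit of > 100000 nM in this assay, at which 1 of the 3 values shown sits. Among the compounds with values here, no single-point step between measured compounds is available, so the step to compound 4 is read from the structures alone.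

Compound 4 `CCOc1ccccc1NC(=O)CSc1c[nH]c2cccc(OC)c12` differs from compound 3 by methoxy in place of chloro on an aromatic carbon of the core. Within the three compounds shown, changes on the core of this kind are not isolated, so no measured step can be cited for it. The change from compound 3 to compound 4 is expected to move the number in this assay upward by a modest amount, a 1.6-fold higher number from compound 3 to compound 4 (0.20 log units; within the scatter), at the edge of the scatter. Compound 4 is thus estimated at 40000 nM, with a range from 15000 nM to 100000 nM in this assay.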

Compound 4, half-maximal cytotoxic concentration: > 100000 nM
Compound 4: only a limit was reported; the forecaster's own chance of this, stated with the estimate: 30%; middle value at least 2.5-fold (0.39 log units) away from the limit.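

In this assay, within the data shown here, methoxy in place of chloro on this aromatic carbon of the core gives the first single-place comparison, an at least 3.9-fold higher number from compound 3 to compound 4 (0.59 log units; beyond the scatter). Compound 4 gives > 100000 nM, which is a limit and not a number. The step therefore has a floor but no upper end, though it does show that the group at this position can shift the read-out by more than the scatter, and its full size cannot be read because compound 4 sits at the limit: the limit of > 100000 nM in this assay, at which 2 of the 4 values shown sit.

As far as these compounds go, how far compound 4 lies past that limit stays open, as does whether the same change moves the number in other members. From the compounds shown here alone, it is also open where an amine or a carboxylic acid at this position would fall relative to chloro and methoxy.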